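Adding a hydroxy to compound 2: working notes

The compounds below may be only part of what the source reports. "The series", "measured", "known", "first", "only" and "open" are said of these compounds alone.

Measured so far:
- Compound 1 (`COc1cccc(-c2ccc(O)cc2)c1`) gives 41 ug/mL
- Compound 2 (`COc1ccc(-c2ccccc2)cc1OC`) gives 45 ug/mL

Both values come from a functional assay on MCF7 cells (Homo sapiens) for cytotoxicity, read by MTT assay, with a stated time of 3 days (a higher number here means a weaker inhibitor, a lower number a stronger inhibitor), and lie within the scatter of each other. Compound 2 therefore stands level with compound 1, and the pair shows no order.

The next structure is compound 3 (`COc1ccc(-c2ccc(O)cc2)cc1OC`). It is reached from compound 2 by hydroxy in place of hydrogen on an aromatic carbon, para to a large group (hydroxy in place of hydrogen on an aromatic carbon).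

Among the measured compounds shown here, no measured pair isolates this change, so the expectation rests on little. Compound 1, which also carries a hydroxy, gives 41 ug/mL in this assay and that value sits within the scatter of compound 2. On this basis no step beyond the scatter is expected, although a slightly lower number remains possible. The expected change is a 1.4-fold lower number from compound 2 to compound 3 (0.15 log units; within the scatter) and it is estimated to stay within the scatter. For compound 3 the estimated value is 32 ug/mL (expected range 14 ug/mL to 65 ug/mL).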

Compound 3, half-maximal inhibitory concentration: 34 ug/mL
For compound 3 the middle estimate is 1.1-fold (0.03 log units) below the measured one; low and high end bracket the measured number.
By their numbers in this assay, from the lowest: compounds 3, 1 and 2 (each within the scatter of the next).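

Among the compounds shown here, the pair of compound 2 and compound 3 isolates hydroxy in place of hydrogen on an aromatic carbon, para to a large group, for the first time in this assay and gives a 1.3-fold lower number from compound 2 to compound 3 (0.12 log units; within the scatter), so this change has no effect that can be told from the scatter. The second single change, an added methoxy, gives a 1.2-fold lower number from compound 1 to compound 3 (0.08 log units; within the scatter), and it too stays within the scatter. Compound 3 therefore carries both groups without leaving the level of compound 1 and compound 2, and neither step gives the series an order in this assay.

The compounds shown leave open whether any group at this position can produce a step beyond the scatter, since hydroxy is the only replacement for hydrogen there. An amine, a carboxylic acid or a longer chain such as ethoxy in the same place would test whether this flat reading holds beyond hydroxy. No independent measurement accompanies these values to connect the steps with any property of the compounds.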